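The source may hold more compounds than are shown below. What is called first, only, known or untested is meant among the compounds shown, and "the series" means these compounds.

Of the compounds shown here, three of one shared core have been measured in a functional assay on L1210 cells (Mus musculus), with a stated time of 12 days; on this read-out higher numbers stand for higher potency (the scale is a negative logarithm) and lower numbers for lower potency. Compound 1 `CC1=C(N2CC2)C(=O)C(N2CC2)=C(N2CC2)C1=O` gives 6.77. Compound 2 `COC(CO)C1=C(N2CC2)C(=O)C(C)=C(N2CC2)C1=O` gives 6.9, and the step of a number 0.13 log units higher from compound 1 to compound 2 (within the scatter) is within the scatter, so the two cannot be ranked. Compound 3 `CC1=C(N2CC2)C(=O)C(Cc2ccccc2)=C(N2CC2)C1=O` gives 4.85, the lowest of the three numbers; the steps of a number 1.92 log units lower from compound 1 to compound 3 (beyond the scatter) and a number 2.05 log units lower from compound 2 to compound 3 (beyond the scatter) are both large, so compound 3 stands clearly apart from the other two.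

Compound 4 `CC1=C(N2CC2)C(=O)C(C(C)C)=C(N2CC2)C1=O` differs from compound 3 in one place: isopropyl in place of benzyl on a double-bonded ring carbon. For the measured compounds named here, no measured step replaces benzyl with isopropyl, so the two large drops to compound 3 bear on it only indirectly: among the measured compounds, the one carbon-only substituent at this carbon is the benzyl of compound 3, and it carries the lowest number, while the higher numbers belong to substituents containing nitrogen or oxygen. Isopropyl is again carbon only, but is not benzyl, so the expectation in this assay is a modest rise with wide uncertainty, the estimated step being a number 0.65 log units higher from compound 3 to compound 4 (beyond the scatter). Compound 4 is therefore estimated at 5.5, with a range from 4.7 to 6.5.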

Compound 4, logarithm of the reciprocal of the active concentration, log(1/C): 5.6
Compound 4: middle estimate off by 0.10 log units, on the low side, and the stated range covers the measured number.
By their numbers in this assay, from the lowest: compound 3; then compound 4; then compounds 1 and 2 (each within the scatter of the next).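

In this assay the change from benzyl to isopropyl gives a number 0.75 log units higher from compound 3 to compound 4 (beyond the scatter) and so shows that two carbon-only groups at this double-bonded ring carbon need not give the same number. Isopropyl still falls short of the two groups containing oxygen or nitrogen, with a number 1.30 log units lower from compound 2 to compound 4 (beyond the scatter) for the swap from 2-hydroxy-1-methoxyethyl and a number 1.17 log units lower from compound 1 to compound 4 (beyond the scatter) for the swap from aziridin-1-yl, so leaving benzyl behind closes only part of the gap. Nothing measured here explains why these groups differ.

Isopropyl differs from benzyl both in having fewer heavy atoms and in having no ring, and these two changes cannot be separated with the compounds shown. A cyclohexyl group would help to separate them, while a simple amine or a hydroxymethyl group would test whether the higher numbers depend on nitrogen or oxygen at this carbon.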